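The compounds below may be only part of what the source reports. "The series", "measured", "known", "first", "only" and "open" are said of these compounds alone.

Measured so far:
Compound 1 `C#Cc1cccc(NC(=O)CCc2cccc3c2B(O)OC3)c1` gives 1600 nM.
Compound 2 `C#Cc1ccccc1NC(=O)CCc1cccc2c1B(O)OC2` gives 1300 nM.
Compound 3 `O=C(CCc1cccc2c1B(O)OC2)Nc1ccccc1-c1ccccc1` gives 18000 nM.

These three compounds were tested in a functional assay on MDA-MB-231 cells (Homo sapiens) for antiproliferative activity, read by MTT assay, with a stated time of 72 h; on this read-out lower numbers stand for stronger inhibition and higher numbers for weaker inhibition. The cores of compound 1 and compound 2 hold the same atoms joined differently; the difference between the two cores is not broken down here. From compound 2 to compound 3 the change is phenyl in place of ethynyl on an aromatic carbon, and it made a large step of a 14-fold higher number from compound 2 to compound 3 (1.14 log units; beyond the scatter). Compound 4 `O=C(CCc1cccc2c1B(O)OC2)Nc1cccc(-c2ccccc2)c1` is not yet measured. From compound 1 to compound 4 the change is phenyl in place of ethynyl on an aromatic carbon, the same kind of change, though here the place is meta to a large group rather than ortho to a large group. Because compound 1 gives 1600 nM and the earlier step was a 14-fold higher number from compound 2 to compound 3 (1.14 log units; beyond the scatter), a similar step of a 13-fold higher number from compound 1 to compound 4 (1.10 log units; beyond the scatter) is expected. Compound 4 is therefore estimated at 20000 nM, likely between 7000 nM and 60000 nM.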

Compound 4, half-maximal inhibitory concentration: 220 nM
Compound 4: the middle estimate sits 91-fold (1.96 log units) above what was measured, outside the stated range (below it).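

In this assay, phenyl in place of ethynyl gave a 7.3-fold lower number from compound 1 to compound 4 (0.86 log units; beyond the scatter), the opposite direction to the earlier step. The swap therefore does not carry over from one core to the other, neither in size nor in direction: the same change on two cores in this assay, a 14-fold higher number (1.14 log units; beyond the scatter) from compound 2 to compound 3 and a 7.3-fold lower number (0.86 log units; beyond the scatter) from compound 1 to compound 4, 100-fold (2.00 log units) apart, beyond the scatter of two such steps. This shows that a step measured on one core cannot simply be transferred to the other in this series, but two pairs cannot show what sets the difference or how the swap would behave on any further core.

The compounds shown carry only ethynyl or phenyl at this place, so it remains open whether an amine or a carboxylic acid there would follow compound 3 or compound 4. From the compounds shown here alone, it is also open whether a longer chain joining the amide to the core would change the picture.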